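The source may report more compounds than this note shows. Statements on the series, on what has been measured and on what is new or still open speak of the compounds shown alone.

Compound 1 `COc1ccc(-c2cnc(NC(=O)c3ccccc3OC)n2C)cc1` was tested in a toxicity assay on THP-1 cells (Homo sapiens) for inhibition; a higher number here means that more compound is tolerated, a lower number that less compound is tolerated. In this assay compound 1 gives only a limit, > 100000 nM, so no number is known for it. Compound 2 `Cc1ccccc1C(=O)Nc1ncc(-c2ccccc2)n1C` also gives only a limit in this assay, > 100000 nM. Compound 3 `Cc1ccc(-c2cnc(NC(=O)c3ccc(F)cc3)n2C)cc1` gives a measured value of 60000 nM in this assay. Going by the values given here, compound 1 thus stands at the limit of > 100000 nM in this assay, at which 2 of the 3 values shown sit, with compound 2 beside it and compound 3 as the only compound with a number.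

The step to compound 4 `COc1ccc(-c2cnc(NC(=O)c3ccc(C)cc3)n2C)cc1` changes one group on the shared core: 4-methylphenyl in place of 2-methoxyphenyl on a carbonyl carbon. Among the compounds with values here, no step between two measured compounds is available to set the size of this change, and compound 3, which carries no methoxy group at all, sits not far from the limit. The change is expected to stay within the usual scatter, so for compound 4 a value near the limit is estimated, 100000 nM, within 40000 nM to 250000 nM, and a step of a number no higher from compound 1 to compound 4 (the limit leaves the size open) is expected.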

Compound 4, half-maximal cytotoxic concentration: > 100000 nM
Compound 4: only a limit was reported; the forecaster's own chance of this, stated with the estimate: 60%; the middle value sits exactly at the limit.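

Compound 1 and compound 4 both give only a limit in this assay, so no step can be read between them: the limit of > 100000 nM in this assay, at which 3 of the 4 values shown sit.

The compounds shown leave open whether 4-methylphenyl in place of 2-methoxyphenyl changes how much compound the cells tolerate.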